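Swapping a chloro for a nitro on the phenyl ring

The compounds below may be only part of what the source reports. "The series", "measured", "known", "first", "only" and "open" are said of these compounds alone.

Compound 3 `O=c1ccc2cc(OCc3cc(-c4ccc(Cl)cc4)no3)ccc2o1` was tested in a functional assay on HL-60 cells (Homo sapiens) for cytotoxicity, read by MTT assay, with a stated time of 48 h (a lower number here means a stronger inhibitor, a higher number a weaker inhibitor), where compound 3 gives 44600 nM. Going by the values given here, this is one of only two numbers available, and the other belongs to compound 1 `O=c1ccc2cc(OCc3cc(-c4ccccc4)no3)ccc2o1`, which in this assay gives 43300 nM; the step of a 1.0-fold higher number from compound 1 to compound 3 (0.01 log units; within the scatter) lies within the scatter. Compound 2 `COc1cccc(-c2cc(COc3ccc4oc(=O)ccc4c3)on2)c1` has no usable number, its entry reading "not determined" (no result reported). Compound 4 `O=c1ccc2cc(OCc3cc(-c4cccc([N+](=O)[O-])c4)no3)ccc2o1` differs from compound 3 by 3-nitrophenyl in place of 4-chlorophenyl on an aromatic carbon. Among the compounds with values here, only the step from compound 1 to compound 3 concerns a change on this phenyl ring, and it stayed within the scatter, so no shift beyond the scatter is expected in this assay. Compound 4 is therefore estimated at 45000 nM, within 20000 nM to 100000 nM. This expectation corresponds to the step of a 1.0-fold higher number from compound 3 to compound 4 (0.00 log units; within the scatter).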

Compound 4, half-maximal inhibitory concentration: 44400 nM
Beside the measured number, compound 4's estimate is 1.0-fold (0.01 log units) above it; measured number inside the range.
By their numbers in this assay, from the lowest: compounds 1, 4 and 3 (each within the scatter of the next).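

In this assay the step of a 1.0-fold lower number from compound 3 to compound 4 (0.00 log units; within the scatter) shows that 3-nitrophenyl and 4-chlorophenyl cannot be told apart at this position on the five-membered ring. Against the plain phenyl group, the step of a 1.0-fold higher number from compound 1 to compound 4 (0.01 log units; within the scatter) gives the same picture, so nitro joins chloro as a second group on this phenyl ring that leaves the number unmoved. No measurement available here offers an explanation for this flat result.

As far as these compounds go, whether an amine or a carboxylic acid on this phenyl ring would shift the number stays open. So does the outcome of replacing the phenyl ring itself.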